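This account rests on a few compounds, and the source may have more. Where it says the series, first, only, none or still open, it means among the compounds named here.

Measured values in a functional assay on KB cells (Homo sapiens) for antiproliferative activity; a lower number here means a stronger inhibitor, a higher number a weaker inhibitor:
Compound 1 `CSc1nc2c(C)nsc2[nH]1` gives 60000 nM.
Compound 2 `CSc1nc2snc(C)c2n1[C@H]1C[C@H](O)[C@@H](CO)O1` gives 30000 nM.
Compound 3 `CSc1nc2sncc2n1[C@H]1C[C@H](O)[C@@H](CO)O1` gives 6000 nM.

Compound 3 stands lowest of the three numbers in this assay; compound 2 is the nearest of the other two and compound 1 the furthest, both separated from compound 3 by more than the scatter. Among the measured compounds shown here, the only single-change step among the measured compounds, hydrogen in place of methyl on an aromatic carbon, reads a 5.0-fold lower number from compound 2 to compound 3 (0.70 log units; beyond the scatter), a modest shift.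

Compound 4 `OC[C@H]1O[C@@H](n2c(SCc3ccccc3)nc3sncc32)C[C@@H]1O` differs from compound 3 by phenyl in place of hydrogen on a saturated chain carbon bound to a sulfur. For the measured compounds named here, no measured step touches the methylsulfanyl group; the change between compound 2 and compound 3 sits on a different part of the shared core and so gives no direct guide to what enlarging the sulfur substituent to benzylsulfanyl does. The series offers nothing else to lean on, so the expectation rests on compound 3 alone, with a wide range to cover a shift of modest size in either direction. Compound 4 is expected to give 3000 nM in this assay, within 600 nM to 15000 nM. The step this estimate implies is expected to be a 2.0-fold lower number from compound 3 to compound 4 (0.30 log units; within the scatter), small against the scatter.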

Compound 4, half-maximal inhibitory concentration: 3000 nM
For compound 4 middle estimate and measured number coincide at the digits printed; low and high end bracket the measured number.
By their numbers in this assay, from the lowest: compounds 4 and 3 (each within the scatter of the next); then compounds 2 and 1 (each within the scatter of the next).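

In this assay, the only step shown at the sulfur substituent, methylsulfanyl to benzylsulfanyl, reads a 2.0-fold lower number from compound 3 to compound 4 (0.30 log units; within the scatter) and so cannot be told apart from repeat measurement. The earlier step, a 5.0-fold lower number from compound 2 to compound 3 (0.70 log units; beyond the scatter), sat on a different part of the shared core and said nothing about this position; the new step shows that phenyl, with its 6 heavy atoms, can enter on the saturated chain carbon bound to a sulfur without a change beyond the scatter in this assay. No measurement bearing on this result accompanies the series, and the numbers alone offer no explanation for it.

Going by these compounds, whether this insensitivity extends beyond phenyl remains open: a longer chain such as propyl at the same place, or a phenyl ring carrying an amine or a carboxylic acid, could read differently. On these data alone, it is also open whether the step from methyl to hydrogen on the aromatic carbon keeps its size when the sulfur carries benzyl rather than methyl, since that step is known only with methylsulfanyl in place.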